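This account rests on a few compounds, and the source may have more. Where it says the series, first, only, none or still open, it means among the compounds named here.

Measured compounds in a functional assay on ileum (strain Hartley) for agonist activity at 5-hydroxytryptamine receptor 3A (Cavia porcellus); a lower number here means a less potent compound, a higher number a more potent compound, by a factor of ten per unit of this negative logarithm:
compound 1 `CCc1cccc2nc(N3CCN(C)CC3)oc12` gives 5.48
compound 2 `CN1CCN(c2nc3cc([N+](=O)[O-])ccc3o2)CC1` gives 6.1
compound 3 `CCc1cc(Cl)cc2nc(N3CCN(C)CC3)oc12` gives 6.82

Compound 3 holds the highest number of the three in this assay; compound 2 stands nearest to it and compound 1 furthest, both lower and both beyond the scatter. Among the compounds with values here, the only step between measured compounds that differ in one place is a number 1.34 log units higher from compound 1 to compound 3 (beyond the scatter), a large one. The unmeasured compound 4 `Cc1cc(Cl)cc2nc(N3CCN(C)CC3)oc12` differs from compound 3 as follows: hydrogen in place of methyl on a saturated chain carbon bound to an aromatic carbon. Within the data shown here, no measured step touches this place. The step from compound 1 to compound 3 concerns chloro in place of hydrogen on an aromatic carbon, and compound 2 differs from the others in more than one place, so its number says nothing about the ethyl group on its own. With nothing to go on but the small size of the change, the step in this assay is expected to stay within the scatter, a number 0.12 log units lower from compound 3 to compound 4 (within the scatter). Compound 4 is therefore estimated at 6.7, with a range from 6.1 to 7.3.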

Compound 4, negative logarithm of the half-maximal effective concentration: 6.7
Compound 4: middle estimate and measured number agree at the digits printed; the range from low to high includes it.
By their numbers in this assay, from the lowest: compound 1; then compound 2; then compounds 4 and 3 (each within the scatter of the next).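

In this assay the difference of ethyl to methyl at this place gives a number 0.12 log units lower from compound 3 to compound 4 (within the scatter), so compound 3 and compound 4 cannot be told apart here. Within the data shown here, this is the first step read at the saturated chain carbon bound to an aromatic carbon, and it shows that, with chloro present on the core, one chain carbon more or less has no effect beyond the scatter. No measurement at hand explains why this place is so insensitive to the change.

On these data alone, whether ethyl to methyl reads the same without the chloro group, on the core of compound 1, stays open. Also open, as far as these compounds go, is how a longer chain such as propyl, or a primary amine or a carboxylic acid at this place, would stand in this assay.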